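The source may report more compounds than this note shows. Statements on the series, on what has been measured and on what is new or still open speak of the compounds shown alone.

Compound 1 `O=C(c1ccc(C(F)(F)F)cc1)N1CCC(NS(=O)(=O)c2cc(S(=O)(=O)c3ccccc3)ccc2C(F)(F)F)CC1` gives 6300 nM in a physicochemical assay for solubility; a lower number here means a less soluble compound, a higher number a more soluble compound. Compound 2 `O=C(c1cccnc1)N1CCC(NS(=O)(=O)c2cc(S(=O)(=O)c3ccccc3)ccc2C(F)(F)F)CC1` gives 50000 nM in the same assay, and compound 3 `O=C(O)c1cccc(S(=O)(=O)N2CCC(NS(=O)(=O)c3cc(S(=O)(=O)c4ccccc4)ccc3C(F)(F)F)CC2)c1` gives 12500 nM. Compound 2 holds the highest of the three numbers: the step from compound 1 to compound 2 is a 7.9-fold higher number from compound 1 to compound 2 (0.90 log units; beyond the scatter), and the step from compound 2 to compound 3 is a 4.0-fold lower number from compound 2 to compound 3 (0.60 log units; beyond the scatter), both beyond the scatter. The step from compound 1 to compound 3, a 2.0-fold higher number from compound 1 to compound 3 (0.30 log units; within the scatter), stays within the scatter.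

Compound 4 `CC(C)(O)CCN1CCC(NS(=O)(=O)c2cc(S(=O)(=O)c3ccccc3)ccc2C(F)(F)F)CC1` has not been measured in this assay. It differs from compound 2 as follows: 3-hydroxy-3-methylbutyl in place of (pyridin-3-yl)carbonyl on an amine nitrogen in a ring. Both measured steps change the same group on the amine nitrogen in a ring and so bear on this one. They show that exchanging the group at this position shifts the number by modest amounts in either direction, one step rising beyond the scatter and one falling beyond it. For the measured compounds named here, the group entering here resembles none of the three groups already measured, so no step gives a direct analogue. The expected step from compound 2 to compound 4 is therefore a 1.6-fold higher number from compound 2 to compound 4 (0.20 log units; within the scatter), small and uncertain in direction. Compound 4 is estimated at 80000 nM, with a range from 25000 nM to 250000 nM.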

Compound 4, solubility: 50000 nM
Compound 4: middle estimate off by 1.6-fold (0.20 log units), on the high side; the range from low to high includes it.
By their numbers in this assay, from the lowest: compounds 1 and 3 (each within the scatter of the next); then compounds 2 and 4 (each within the scatter of the next).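

At the amine nitrogen in a ring, in this assay, 3-hydroxy-3-methylbutyl and (pyridin-3-yl)carbonyl cannot be told apart (no change at the digits printed from compound 2 to compound 4 (within the scatter)), so among the compounds shown neither a ring nor a carbonyl on this nitrogen is required to reach the top of the series. The same group also stands clear of the other two groups at this position (a 4.0-fold higher number from compound 3 to compound 4 (0.60 log units; beyond the scatter); a 7.9-fold higher number from compound 1 to compound 4 (0.90 log units; beyond the scatter)), which repeats the sizes of the steps already seen for (pyridin-3-yl)carbonyl and gives the top of the series two groups of very different build. Nothing measured here gives a reason why two such unlike groups match.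

Still open, going by these compounds, is whether the hydroxy group of the chain counts at all, which a plain 3-methylbutyl chain would test, along with whether a shorter or longer chain carrying the same hydroxy group stays level with these two. A carboxylic acid at the end of a chain, or pyridin-3-yl joined through a sulfonyl in place of the carbonyl, would help separate the part played by the linking group from that of the group it carries.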